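The source may hold more compounds than are shown below. What is called first, only, known or untested is meant among the compounds shown, and "the series" means these compounds.

Compound 1, `CC(C)=CC[C@@H](OC(=O)c1ccco1)C1=CC(=O)c2c(O)ccc(O)c2C1=O`: 80300 nM
Compound 2, `CCCCC(O)CC(=O)O[C@H](CC=C(C)C)C1=CC(=O)c2c(O)ccc(O)c2C1=O`: 72200 nM
Compound 3, `CCCC(CC(=O)O[C@H](CC=C(C)C)C1=CC(=O)c2c(O)ccc(O)c2C1=O)OC(C)=O`: 51200 nM

All three were tested in a functional assay on HeLa cells (Homo sapiens) for cytotoxicity, read by MTT assay; a higher number here means a weaker inhibitor, a lower number a stronger inhibitor. Compound 2 stands second highest of the three numbers; its neighbours sit close on either side, with the step of a 1.1-fold lower number from compound 1 to compound 2 (0.05 log units; within the scatter) and the step of a 1.4-fold lower number from compound 2 to compound 3 (0.15 log units; within the scatter) both within the scatter, as is the step of a 1.6-fold lower number from compound 1 to compound 3 (0.20 log units; within the scatter).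

Compound 4, `CC(C)=CC[C@@H](OC(=O)CC(C)(O)C(C)C)C1=CC(=O)c2c(O)ccc(O)c2C1=O`, has not yet been measured in this assay. It differs from compound 2 in one place: 1-hydroxy-1,2-dimethylpropyl in place of 1-hydroxypentyl on a saturated chain carbon bound to a carbonyl carbon.

Among the compounds with values here, the step that bears most directly on this change is the one from compound 2 to compound 3, which also alters the saturated chain carbon bound to the carbonyl carbon and gave a 1.4-fold lower number from compound 2 to compound 3 (0.15 log units; within the scatter). The two steps that replace the whole acyl group, a 1.1-fold lower number from compound 1 to compound 2 (0.05 log units; within the scatter) and a 1.6-fold lower number from compound 1 to compound 3 (0.20 log units; within the scatter), were likewise within the scatter. Nothing among these compounds suggests that rearranging the side chain shifts the number beyond the scatter, so no step beyond the scatter is expected in this assay.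

Compound 4 is therefore estimated at 70000 nM, in the range 40000 nM to 130000 nM, which means an expected step of a 1.0-fold lower number from compound 2 to compound 4 (0.01 log units; within the scatter).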

Compound 4, half-maximal inhibitory concentration: 27700 nM
For compound 4 the middle estimate is 2.5-fold (0.40 log units) above the measured one, outside the stated range (below it).
By their numbers in this assay, from the lowest: compounds 4, 3, 2 and 1 (each within the scatter of the next, the first and the last beyond it).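

In this assay, within the data shown here, the group on the saturated chain carbon bound to a carbonyl carbon proved able to move the number with no change in its atoms: 1-hydroxy-1,2-dimethylpropyl in place of 1-hydroxypentyl gave a 2.6-fold lower number from compound 2 to compound 4 (0.42 log units; beyond the scatter), the first step at this position beyond the scatter, and 2-hydroxy-2,3-dimethylbutyl in place of furan-2-yl on a carbonyl carbon gave a 2.9-fold lower number from compound 1 to compound 4 (0.46 log units; beyond the scatter). Set against 1-acetoxybutyl, the same group gave a 1.8-fold lower number from compound 3 to compound 4 (0.27 log units; within the scatter), so those two compounds cannot be ranked. No measurement offered here accounts for the step.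

Going by these compounds, it stays open whether the hydroxy group or the branching of 1-hydroxy-1,2-dimethylpropyl carries the step. Also open, on these data alone, is what an amine, a carboxylic acid or a longer chain would do at this position.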